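Pentyl on selenium: carrying the step to the amine core

A few compounds are considered here, and "the series" means these few. Any claim that something is new, unique, unknown or untested is made for them only; others in the source may bear on it.

Compound 3, `Nc1nc([SeH])nc2ccccc12`, gives the lowest number of the three measured in an ADME assay on 184B5 cells (Homo sapiens) for cytotoxicity, read by MTT assay, with a stated time of 72 h (on this read-out lower numbers stand for stronger inhibition of growth and higher numbers for weaker inhibition of growth), at 690 nM. Compound 2, `[SeH]c1nc(NCc2ccccc2)c2ccccc2n1`, shares the hydrogen on the selenium but carries a different core; in this assay compound 2 gives 20800 nM. How the two cores differ is not broken down here. Compound 1, `CCCCC[Se]c1nc(NCc2ccccc2)c2ccccc2n1`, is compound 2 with pentyl in place of hydrogen on a selenium; in this assay compound 1 gives 70900 nM. That change made a 3.4-fold higher number from compound 2 to compound 1 (0.53 log units; beyond the scatter).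

Compound 4, `CCCCC[Se]c1nc(N)c2ccccc2n1`, is the same change applied to compound 3: pentyl in place of hydrogen on a selenium. The place is identical in both pairs, a selenium whose other neighbour is aromatic carbon, so the change is taken as the same one, seen only once as a measured step.

The expectation rests on that single step: compound 4 is expected to sit near 2400 nM in this assay. The expected step is a 3.5-fold higher number from compound 3 to compound 4 (0.54 log units; beyond the scatter), matching the size seen for compound 1 against compound 2. With one precedent only, the estimate is expected to fall between 1000 nM and 6000 nM.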

Compound 4, concentration for 50% growth inhibition: 15300 nM
The estimate for compound 4 lay 6.4-fold (0.80 log units) below the measured number, and the stated range ends below it.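

Pentyl in place of hydrogen on a selenium gives a higher number in this assay on both cores, so the direction carries over, but the size does not: the same change on two cores in this assay, a 3.4-fold higher number (0.53 log units; beyond the scatter) from compound 2 to compound 1 and a 22-fold higher number (1.35 log units; beyond the scatter) from compound 3 to compound 4, 6.5-fold (0.81 log units) apart, beyond the scatter of two such steps. On the core of compound 3 the change gives a 22-fold higher number from compound 3 to compound 4 (1.35 log units; beyond the scatter), so the step seen on the core of compound 2 does not serve as a fixed increment for this series. With pentyl kept, hydrogen in place of benzyl on a nitrogen on an aromatic ring gives a 4.6-fold lower number from compound 1 to compound 4 (0.67 log units; beyond the scatter); these pairs show that the size of the pentyl step differs between two cores, but they do not show why, or what it would be on a third core.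

Still open, from the compounds shown here alone, is whether the gap between the two steps is specific to benzyl on the nitrogen or would also appear with a smaller group such as methyl there. Also open, going by these compounds, is how the number moves along the chain on selenium, from methyl or propyl to a longer chain such as octyl, on either core.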